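This account rests on a few compounds, and the source may have more. Where it says the series, first, only, none or still open, it means among the compounds named here.

Two pairs of compounds share the same small structural change here. Compound 1, with the structure `O=S(=O)(c1ccc(F)cc1)N(Cc1ccccc1)Cc1cccc(F)c1F`, is measured in a functional assay on 3T3-L1 cells (Mus musculus) for inhibition, with a stated time of 20 min, tested at 20 uM (a lower number here means less inhibition, a higher number more inhibition at the concentration tested (going by the name of the read-out)), and gives -81.9%. Compound 2, with the structure `Cc1ccc(S(=O)(=O)N(Cc2ccccc2)Cc2cccc(F)c2F)cc1`, gives -35.7%. The change between them is methyl in place of fluoro on an aromatic carbon, and it made a step of a number 46.2 percentage points higher from compound 1 to compound 2 (beyond the scatter). Compound 3, with the structure `CC(=O)N(Cc1cccc(F)c1F)Cc1cn(S(=O)(=O)c2ccc(F)cc2)c2ccccc12`, is built on a different core, and the difference between the two cores is not broken down here; in this assay compound 3 gives 25.8%, the highest of the three measured numbers. Among the measured compounds shown here, compound 4, with the structure `CC(=O)N(Cc1cccc(F)c1F)Cc1cn(S(=O)(=O)c2ccc(C)cc2)c2ccccc12`, has not yet been measured; it differs from compound 3 by methyl in place of fluoro on an aromatic carbon, which is the same change, at the same place, as the one that separates compound 1 from compound 2. For the measured compounds named here, because the change from compound 1 to compound 2 gave a number 46.2 percentage points higher from compound 1 to compound 2 (beyond the scatter), a step of similar direction and size is expected from compound 3 to compound 4, though only one earlier example supports this and the cores differ; the expected step is a number 29.2 percentage points higher from compound 3 to compound 4 (beyond the scatter). Compound 4 is therefore estimated to give 55% in this assay, between 20% and 85%.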

Compound 4, a percentage reported as inhibition, at one concentration (the size of the read-out at that concentration, not a potency): 57.5%
Compound 4: the middle estimate sits 2.5 percentage points below what was measured; measured number inside the range.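

Replacing fluoro with methyl on the aromatic carbon gave a number 31.7 percentage points higher from compound 3 to compound 4 (beyond the scatter) in this assay, so the number rose on the core of compound 3 just as it did on the core of compound 1. The direction of the change carried over from one core to the other, but its size did not stay the same: the same change on two cores in this assay, a number 46.2 percentage points higher (beyond the scatter) from compound 1 to compound 2 and a number 31.7 percentage points higher (beyond the scatter) from compound 3 to compound 4, 14.5 percentage points apart, beyond the scatter of two such steps. Among the compounds shown here, with only one pair on each core, these results do not explain why the two steps differ in size, and they cannot show that the number would rise on any further core.

The compounds shown compare only fluoro and methyl at this place, on an aromatic carbon para to a large group, so the effect of a methoxy group, a chlorine atom or an amine there remains open. Also open, going by these compounds, is how these compounds would compare at other concentrations, as each number comes from a single tested concentration and is not a potency.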